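Swapping the aryl group on the outer amide

This account rests on a few compounds, and the source may have more. Where it says the series, first, only, none or still open, it means among the compounds named here.

Measured so far:
compound 1, `CN(C)C(=O)c1cc2cnc(Nc3ccc(NC(=O)C4(C(=O)Nc5ccccc5)CC4)cc3)nc2n1C1CCCC1`, gives 93.9% in a functional assay on T47D cells (Homo sapiens) for inhibition, read by CCK-8 assay, with a stated time of 72 h, tested at 10 uM; a lower number here means less inhibition of growth, a higher number more inhibition of growth at the concentration tested.
compound 2, `CN(C)C(=O)c1cc2cnc(Nc3ccc(NC(=O)C4(C(=O)Nc5ccccc5F)CC4)cc3)nc2n1C1CCCC1`, gives 97.8% in this assay.

Among the measured compounds shown here, compound 2 stands highest of the two numbers seen in this assay, with compound 1 nearest; the single step of a number 3.9 percentage points higher from compound 1 to compound 2 (within the scatter) lies within the scatter, so the two compounds cannot be told apart on these data.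

Compound 3, `CN(C)C(=O)c1cc2cnc(Nc3ccc(NC(=O)C4(C(=O)Nc5ccc(Br)cc5)CC4)cc3)nc2n1C1CCCC1`, has not yet been measured. It differs from compound 2 only at the outer amide: 4-bromophenyl in place of 2-fluorophenyl on an amide-type nitrogen

For the measured compounds named here, only one measured step bears on this change, and it touches the same aryl group: a number 3.9 percentage points higher from compound 1 to compound 2 (within the scatter), a change within the scatter, from an unsubstituted phenyl to a 2-fluorophenyl. A second change of the substituent on that phenyl is therefore expected to leave the growth inhibition in this assay close to where both measured compounds already sit. For compound 3 the step of a number 3.8 percentage points lower from compound 2 to compound 3 (within the scatter) is expected to stay within the scatter. Compound 3 is thus estimated at 94%, in the range from 80% to 99%.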

Compound 3, percent growth inhibition at one concentration: 94.3%
For compound 3 the middle estimate is 0.3 percentage points below the measured one; the range from low to high includes it.
By their numbers in this assay, from the lowest: compounds 1, 3 and 2 (each within the scatter of the next).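

Compound 3 shows that this aryl group on the amide-type nitrogen tolerates a much larger halogen than fluorine, and at a different ring position, without a step that can be resolved in this assay. The bromo group leaves the reading level with the unsubstituted phenyl, with a number 0.4 percentage points higher from compound 1 to compound 3 (within the scatter), and the exchange of 2-fluorophenyl for 4-bromophenyl, with a number 3.5 percentage points lower from compound 2 to compound 3 (within the scatter), gives no separation either, so all three compounds remain indistinguishable and neither the identity of the halogen nor its place on the ring can be seen to matter here. Nothing available explains this flat result, and the step changes both the halogen and its ring position at once, so the two cannot be separated.

The compounds shown carry only a hydrogen or a single halogen on this phenyl ring, so it remains open whether an amine, a carboxylic acid or a methoxy group there, or a cyclohexyl group in place of the phenyl, would keep growth inhibition at this level. Going by these compounds, with a read-out taken at one concentration, it also remains open whether these three compounds would differ at lower concentrations.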